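Swapping Methoxy for Isopropyl on a Bile Acid Receptor Agonist

The source may hold more compounds than are shown below. What is called first, only, known or untested is meant among the compounds shown, and "the series" means these compounds.

Of the compounds shown here, three built on the same core have been tested in an assay on isolated protein for agonist activity at Bile acid receptor (Homo sapiens), read by AlphaScreen, with a stated time of 30 min; on this read-out lower numbers stand for an effect already at smaller amounts and higher numbers for an effect only at larger amounts of compound. Compound 1 `COc1ccccc1-n1nc(C)c2c1NC(=O)[C@H](C)S[C@@H]2c1ccc(Oc2ccccc2)cc1` gives 3300 nM. Compound 2 `Cc1ccccc1-n1nc(C)c2c1NC(=O)[C@H](C)S[C@@H]2c1ccc(-c2cc3ccccc3o2)cc1` gives 1500 nM, and compound 3 `CCOc1cccc(-c2ccc([C@H]3S[C@@H](C)C(=O)Nc4c3c(C)nn4-c3ccccc3C)cc2)c1` gives 3500 nM. Of these three numbers compound 1 holds the second highest, though its gap to compound 3 lies within the scatter and only its gap to compound 2, which sits at a lower number, is beyond it. For the measured compounds named here, the only step between measured compounds that differ in one place is a 2.3-fold higher number from compound 2 to compound 3 (0.37 log units; beyond the scatter), a modest change at the far end of the molecule, on the ring opposite the one that carries the methoxy group.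

Compound 4 `Cc1nn(-c2ccccc2C(C)C)c2c1[C@@H](c1ccc(Oc3ccccc3)cc1)S[C@@H](C)C(=O)N2` differs from compound 1 in one place: isopropyl in place of methoxy on an aromatic carbon. No measured pair touches this ring, so the data give no direct guide to how such a swap moves the number; the one step shown concerns a different position and was modest. The step of no change at the digits printed from compound 1 to compound 4 (within the scatter) is therefore expected to stay within the scatter. Compound 4 is estimated at 3300 nM, with a range from 1500 nM to 7500 nM.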

Compound 4, half-maximal effective concentration: 1900 nM
Compound 4: middle estimate off by 1.7-fold (0.24 log units), on the high side; the measured number falls inside the stated range.
By their numbers in this assay, from the lowest: compounds 2, 4, 1 and 3 (each within the scatter of the next, the first and the last beyond it).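

In this assay, for the compounds shown here, a 1.7-fold lower number from compound 1 to compound 4 (0.24 log units; within the scatter) is the first reading of a change on this ring, and it cannot be told apart from no effect. The swap from 2-methoxyphenyl to 2-isopropylphenyl replaces a group holding one oxygen and one hydrogen-bond acceptor with a slightly larger all-carbon group holding no acceptor, so in this pair the oxygen of methoxy can be lost without the number moving beyond the usual scatter. No supporting data are available to explain why the number holds at this position.

As far as these compounds go, with only methoxy and isopropyl compared on this carbon, this single pair cannot show how widely the position tolerates change, and it remains open whether a group of a different kind, such as an amine, a carboxylic acid or a longer chain like n-butyl, would give a clear step in either direction. From the compounds shown here alone, it is also open whether the same swap would stay within the scatter in a compound with 1-benzofuran-2-yl at the far end of the molecule, the group carried by compound 2.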